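This account rests on a few compounds, and the source may have more. Where it says the series, first, only, none or still open, it means among the compounds named here.

Measured compounds:

compound 1 `COc1ccc(-c2ccn(CCC(C)C)c(=O)c2C#N)cc1Cl`, in a functional assay on CHO cells for positive allosteric modulation of metabotropic glutamate receptor 2 (Homo sapiens), read by scintillation counting and GTPgammaS binding, with a stated time of 30 min (on this read-out lower numbers stand for an effect already at smaller amounts and higher numbers for an effect only at larger amounts of compound), compound 1 gives 363 nM
compound 2 `CC(C)CCn1ccc(-c2ccc(Oc3ccccc3)cc2)c(C#N)c1=O`, in this assay compound 2 gives 42 nM
compound 3 `CC(C)CCn1ccc(-c2ccc(Oc3ccccn3)cc2)c(C#N)c1=O`, in this assay compound 3 gives 646 nM

Compound 3 stands at the highest number of the three. Its nearest neighbour is compound 1, a gap within the scatter, so no order between the two can be claimed. Among the measured compounds shown here, compound 2 lies well below, and the gap to it is the one measured step that bears here: a 15-fold higher number from compound 2 to compound 3 (1.19 log units; beyond the scatter).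

Compound 4 `Cc1cc(Oc2ccc(-c3ccn(CCC(C)C)c(=O)c3C#N)cc2)ccn1` differs from compound 3 in one place: 2-methylpyridin-4-yl in place of pyridin-2-yl on an oxygen on an aromatic ring. For the measured compounds named here, no measured pair shows a move from a pyridin-2-yl to a 2-methylpyridin-4-yl on the oxygen, so the direction must be read indirectly. Going by the values given here, the single relevant step shows that the identity of the ring on the oxygen moves the number strongly, with pyridin-2-yl the weaker of the two rings seen so far. A different pyridyl attachment carrying a methyl is therefore expected to move the number again, most plausibly downward but with wide uncertainty.

For compound 4 the estimate in this assay is 220 nM, within 60 nM to 800 nM, which is expected to mean a 2.9-fold lower number from compound 3 to compound 4 (0.47 log units; beyond the scatter).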

Compound 4, half-maximal effective concentration: 447 nM
Compound 4: the middle estimate sits 2.0-fold (0.31 log units) below what was measured; the range from low to high includes it.
By their numbers in this assay, from the lowest: compound 2; then compounds 1, 4 and 3 (each within the scatter of the next).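

In this assay, a 1.4-fold lower number from compound 3 to compound 4 (0.16 log units; within the scatter) shows that this swap on the oxygen leaves no readable difference, although both the ring attachment and the methyl differ between the two groups. The large gap to the phenyl ether persists with a second nitrogen-bearing ring, an 11-fold higher number from compound 2 to compound 4 (1.03 log units; beyond the scatter), so at this position both pyridinyl groups shown give higher numbers than phenyl, and no compound shown here goes against this. No measured evidence accounts for the gap between the phenyl and pyridinyl groups.

With the attachment and the methyl changing together, their separate contributions stay unresolved, and an unsubstituted pyridin-4-yl on the oxygen would be needed to divide them. Also open, on these data alone, is how a fluoro or methyl group on the terminal phenyl of compound 2 would affect the number.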